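The compounds below may be only part of what the source reports. "The series", "measured", "known", "first", "only" and "open" are said of these compounds alone.

In a functional assay on NCI/ADR-RES cells (Homo sapiens) for inhibition (on this read-out higher numbers stand for weaker inhibition of growth and lower numbers for stronger inhibition of growth), compound 1 `O=C(/C=C/c1cccc(O)c1)c1cccc(-n2cc(-c3ccccc3)[nH]c2=O)c1` gives 3730 nM, compound 2 `O=C(/C=C/c1cccc(O)c1)c1cccc(-n2cc(-c3ccc(Cl)cc3)[nH]c2=O)c1` gives 2200 nM, and compound 3 `COc1cc(/C=C/C(=O)c2cccc(-n3cc(-c4ccccc4)[nH]c3=O)c2)cc(OC)c1OC` gives 1100 nM, the lowest of the three numbers. Compound 3 lies within the scatter of compound 2 but beyond the scatter from compound 1. Compound 4 `COc1cc(/C=C/C(=O)c2cccc(-n3cc(-c4cc(OC)c(OC)c(OC)c4)[nH]c3=O)c2)cc(OC)c1OC` is compound 3 with 3,4,5-trimethoxyphenyl in place of phenyl on an aromatic carbon. Within the data shown here, no measured step matches this change. Among the measured compounds shown here, the only measured step, a 1.7-fold lower number from compound 1 to compound 2 (0.23 log units; within the scatter), alters the same ring in another way and stays within the scatter. Compounds 1 and 3 differ at a different place, and their two values simply show the lower number for compound 3. With no direct guide, the estimate for compound 4 is 900 nM, within 300 nM to 3000 nM, an expected step of a 1.2-fold lower number from compound 3 to compound 4 (0.09 log units; within the scatter).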

Compound 4, concentration for 50% growth inhibition: 2100 nM
The estimate for compound 4 lay 2.3-fold (0.37 log units) below the measured number; low and high end bracket the measured number.
By their numbers in this assay, from the lowest: compounds 3, 4, 2 and 1 (each within the scatter of the next, the first and the last beyond it).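

Putting 3,4,5-trimethoxyphenyl in place of phenyl on this aromatic carbon gives a 1.9-fold higher number from compound 3 to compound 4 (0.28 log units; within the scatter) in this assay. This position therefore tolerates a group of 12 heavy atoms with 3 hydrogen-bond acceptors in place of one with 6 heavy atoms and none, whereas the earlier step at this ring added only a chloro. No measurement here offers an explanation for this result. Open, on these data alone, is how an amine or a carboxylic acid on this ring would read in this assay. Also open, as far as these compounds go, is whether the trimethoxyphenyl group would give a similar result alongside the hydroxyphenyl end of compound 1.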